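The source may report more compounds than this note shows. Statements on the series, on what has been measured and on what is new or still open speak of the compounds shown alone.

Compound 1 `CCc1nc(C2C(C(=O)OC)=C(C)NC(C)=C2C(=O)OCCc2ccccc2)c(Cl)[nH]1` and compound 2 `CCc1nc(C2C(C(=O)OCCc3ccccc3)=C(C)NC(C)=C2C(=O)OCCc2ccccc2)c(Cl)[nH]1` differ only in one ester chain. In an assay on ileum for inhibition of Voltage-dependent L-type calcium channel subunit alpha-1C (Cavia porcellus) (on this read-out lower numbers stand for stronger inhibition and higher numbers for weaker inhibition), compound 1 gives 0.0309 nM, and compound 2 gives 0.0437 nM, the two numbers sitting within the scatter of each other, since a 1.4-fold higher number from compound 1 to compound 2 (0.15 log units; within the scatter). Compound 3 `CCOC(=O)C1=C(C)NC(C)=C(C(=O)OCCc2ccccc2)C1c1nc(CC)[nH]c1Cl` arises from compound 2 through (hydrogen in place of phenyl on a saturated chain carbon, two bonds along the chain from an oxygen next to a carbonyl group). Going by the values given here, the only measured step, on the other ester chain, was that small one, so the expected step in this assay is a 1.2-fold lower number from compound 2 to compound 3 (0.10 log units; within the scatter), nothing beyond the scatter. Compound 3 is therefore estimated at 0.035 nM, between 0.015 nM and 0.09 nM.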

Compound 3, half-maximal inhibitory concentration: 0.0457 nM
For compound 3 the middle estimate is 1.3-fold (0.12 log units) below the measured one, and the stated range covers the measured number.
By their numbers in this assay, from the lowest: compounds 1, 2 and 3 (each within the scatter of the next).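

In this assay, losing the phenyl from this ester chain makes no reading beyond the scatter, with a 1.0-fold higher number from compound 2 to compound 3 (0.02 log units; within the scatter). Adding a methyl on the same chain carbon of the methyl ester also stays within the scatter, with a 1.5-fold higher number from compound 1 to compound 3 (0.17 log units; within the scatter), so ethyl, like phenethyl, is read alongside the methyl ester at this position. No measurement available here accounts for this flat result. Going by these compounds, what a carboxylic acid or an amine at the end of this chain would give remains open. So does whether the phenethyl ester on the other side of the shared core can be changed in the same way.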